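A few compounds are considered here, and "the series" means these few. Any claim that something is new, unique, unknown or untested is made for them only; others in the source may bear on it.

Compound 3 `CCOC(=O)C(=O)CC(=O)/C=C/c1cn(Cc2ccc(OC)cc2)c2ccccc12` gives in an assay on isolated protein for inhibition of DNA nucleotidylexotransferase (Homo sapiens), read by scintillation counting, with a stated time of 10 min (on this read-out lower numbers stand for stronger inhibition and higher numbers for weaker inhibition), only a limit, > 40 uM. Compound 1 `CCOC(=O)C(=O)CC(=O)/C=C/c1cn(C=C(C)C)c2ccccc12` likewise gives only a limit in this assay, > 40 uM. Compound 2 `CCOC(=O)C(=O)CC(=O)/C=C/c1cn(Cc2ccc(Cl)cc2)c2ccccc12` gives 40 uM in this assay. The steps measured so far all change the group on the aromatic nitrogen or on the aromatic carbon: a number no higher from compound 1 to compound 2 (the limit leaves the size open), a step that the two limits leave unreadable from compound 1 to compound 3 and a number no lower from compound 2 to compound 3 (the limit leaves the size open), none readable in size, as the limit of > 40 uM in this assay, at which 2 of the 3 values shown sit, shows. Compound 4 `COc1ccc(Cn2cc(/C=C/C(=O)CC(=O)C(=O)O)c3ccccc32)cc1` differs from compound 3 by hydrogen in place of ethyl on an oxygen next to a carbonyl group. Among the measured compounds shown here, no measured step touches the oxygen next to a carbonyl group, so none bears on this change, and the size of the step to expect in this assay cannot be read from the series. Compound 4 is estimated at 15 uM, between 2 uM and 60 uM, the expected step being an at least 2.6-fold lower number from compound 3 to compound 4 (0.42 log units; beyond the scatter).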

Compound 4, concentration for 50% inhibition: 10 uM
The estimate for compound 4 lay 1.5-fold (0.18 log units) above the measured number; measured number inside the range.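

Hydrogen in place of ethyl on an oxygen next to a carbonyl group, unlike the earlier steps, gives a step of readable size in this assay: an at least 4.0-fold lower number from compound 3 to compound 4 (0.60 log units; beyond the scatter). This shows that the number in this assay responds to the carboxy end of the molecule, which the changes on the aromatic nitrogen could not show. The true size of the step stays open, with compound 3 held at a limit: the limit of > 40 uM in this assay, at which 2 of the 4 values shown sit.

As far as these compounds go, whether the same change gives a similar step with 4-chlorobenzyl on the aromatic nitrogen remains open. So does whether an amide in place of the carboxy group would keep the number.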